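This account rests on a few compounds, and the source may have more. Where it says the series, first, only, none or still open, it means among the compounds named here.

Measured in a functional assay on HCT-15 cells (Homo sapiens); on this read-out higher numbers stand for an effect only at larger amounts of compound and lower numbers for an effect already at smaller amounts:
- compound 1 `COC(=O)N1N=C(c2ccc(N(C)C)cc2)OC1c1cc(OC)c(OC)c(OC)c1`: 40 uM
- compound 2 `COc1cc(C2OC(c3ccc(N(C)C)cc3)=NN2C(=O)CNC=O)cc(OC)c1OC`: 0.035 uM

Compound 2 holds the lower of the two numbers, 0.035 uM, and so far has only compound 1 for comparison. Compound 3 `COc1cc(C2OC(c3ccc(N(C)C)cc3)=NN2C(=O)CNC(C)=O)cc(OC)c1OC` differs from compound 2 by methyl in place of hydrogen on a carbonyl carbon, which turns formylamino into acetamido. Among the compounds with values here, only one measured step bears on this, a 1100-fold lower number from compound 1 to compound 2 (3.06 log units; beyond the scatter), which is large and beyond the scatter. That step exchanged methoxy for the whole (formylamino)methyl group, so it shows that this part of the molecule can move this assay strongly. It says nothing direct about a single added methyl. A small step towards a higher number is expected, perhaps not beyond the scatter, and the direction is uncertain. The expected change is a 2.0-fold higher number from compound 2 to compound 3 (0.30 log units; within the scatter). For compound 3 the estimated value is 0.07 uM, with an expected range from 0.012 uM to 0.4 uM.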

Compound 3, concentration for half-maximal effect: 0.18 uM
Compound 3: middle estimate off by 2.6-fold (0.41 log units), on the low side; low and high end bracket the measured number.
By their numbers in this assay, from the lowest: compound 2; then compound 3; then compound 1.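

Adding a single methyl on the carbonyl carbon, in this assay, is not a silent change: turning formylamino into acetamido gives (a 5.1-fold higher number from compound 2 to compound 3 (0.71 log units; beyond the scatter)). The position therefore responds to a change of one heavy atom, and not only to the exchange of the whole group. Acetamidomethyl still keeps a wide margin over methoxy (a 220-fold lower number from compound 1 to compound 3 (2.35 log units; beyond the scatter)), so the large gain at this position does not depend on the formyl hydrogen alone. No measurement at hand gives a reason for the difference between formyl and acetyl.

Going by these compounds, with only hydrogen and methyl on this carbonyl carbon, no trend with size can be drawn, and it remains open whether ethyl or a longer chain would push the number further up. Also open, on these data alone, is how an amine or a carboxylic acid would fare in place of the acetamido group.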